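Swapping a Ring Amine for a Methoxy Ester

The source may report more compounds than this note shows. Statements on the series, on what has been measured and on what is new or still open speak of the compounds shown alone.

Compound 1 `CN1CCN(C(=O)/C=C/c2ccncc2-c2ccc3ccccc3c2)CC1`, compound 2 `O=C(O)[C@@H]1CCCN1C(=O)/C=C/c1ccncc1-c1ccc2ccccc2c1` and compound 3 `COC1CN(C(=O)/C=C/c2ccncc2-c2ccc3ccccc3c2)C1` share one core and differ only in the group attached to the carbonyl carbon. In an assay on a protein complex for inhibition of CDK8/Cyclin C (Homo sapiens), with a stated time of 1 h, tested at 10 uM (on this read-out higher numbers stand for more inhibition at the one concentration tested (going by the name of the read-out) and lower numbers for less inhibition), compound 1 gives 101%, compound 2 gives 67% and compound 3 gives 100%. Compound 3 thus stands on the same footing as compound 1 and well above compound 2. Compound 4 `COC(=O)/C=C/c1ccncc1-c1ccc2ccccc2c1` differs from compound 3 by methoxy in place of 3-methoxyazetidin-1-yl on a carbonyl carbon. Within the data shown here, two measured steps touch this carbonyl position: a number 1 percentage points lower from compound 1 to compound 3 (within the scatter), whereas a number 33 percentage points higher from compound 2 to compound 3 (beyond the scatter). Among the measured compounds shown here, no measured step trades the ring amine for a small open-chain group, so in this assay a moderate loss is expected, a number 20 percentage points lower from compound 3 to compound 4 (beyond the scatter). Compound 4 is therefore estimated at 80%, between 50% and 100%.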

Compound 4, a percentage reported as inhibition, at one concentration (the size of the read-out at that concentration, not a potency): 102%
Compound 4: middle estimate off by 22 percentage points, on the low side, and the stated range ends below it.
By their numbers in this assay, from the lowest: compound 2; then compounds 3, 1 and 4 (each within the scatter of the next).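

In this assay the ring amine on the carbonyl carbon can be replaced by plain methoxy with no loss beyond the scatter (a number 2 percentage points higher from compound 3 to compound 4 (within the scatter) and a number 1 percentage points higher from compound 1 to compound 4 (within the scatter)). Neither 3-methoxyazetidin-1-yl nor 4-methylpiperazin-1-yl is therefore required for this read-out, and only 2-carboxypyrrolidin-1-yl stands apart (a number 35 percentage points higher from compound 2 to compound 4 (beyond the scatter)). No evidence on the cause of this is at hand. From the compounds shown here alone, how a dimethylamino group or a longer chain such as butoxy would read at this position remains open. At the single concentration tested, no stronger or weaker effect beyond the scatter is seen among compound 1, compound 3 and compound 4.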